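The source may report more compounds than this note shows. Statements on the series, on what has been measured and on what is new or still open speak of the compounds shown alone.

Measured compounds:
Compound 1, `NS(=O)(=O)c1ccc(/N=C2\NC(=O)/C(=C3/C(=O)Nc4ccc(Cl)cc43)S2)cc1`: in a functional assay on MCF7 cells (Homo sapiens) for antiproliferative activity, read by MTT assay (on this read-out higher numbers stand for weaker inhibition and lower numbers for stronger inhibition), compound 1 gives 3960 nM.
Compound 2, `NS(=O)(=O)c1ccc(/N=C2\NC(=O)/C(=C3/C(=O)Nc4ccc(Br)cc43)S2)cc1`: in this assay compound 2 gives 11300 nM.
Compound 3, `CN1C(=O)/C(=C2\S/C(=N/c3ccc(S(N)(=O)=O)cc3)NC2=O)c2cc(Br)ccc21`: in this assay compound 3 gives 196000 nM.

Compounds 1 and 2 share one core and differ only by chloro in place of bromo on an aromatic carbon. That exchange produces a 2.9-fold lower number from compound 2 to compound 1 (0.46 log units; beyond the scatter). Compound 3 carries a second core, which differs from the core of compound 2 by methyl in place of hydrogen on an amide-type nitrogen in a ring; this single addition gives a 17-fold higher number from compound 2 to compound 3 (1.24 log units; beyond the scatter), and it leaves compound 3 with the highest number of the three measured compounds in this assay.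

Compound 4, `CN1C(=O)/C(=C2\S/C(=N/c3ccc(S(N)(=O)=O)cc3)NC2=O)c2cc(Cl)ccc21`, has not yet been measured. It stands to compound 3 as compound 1 stands to compound 2: the difference is chloro in place of bromo on an aromatic carbon. Since the description of the place is the same word for word in both pairs, this is the same change, now made on the second core; among the compounds shown it appears in these two pairs only.

In this assay, among the compounds with values here, compound 4 is expected to show a 2.2-fold lower number from compound 3 to compound 4 (0.34 log units; beyond the scatter), a step somewhat smaller than the one seen from compound 2 to compound 1, because only a 2.9-fold lower number from compound 2 to compound 1 (0.46 log units; beyond the scatter) is available as a precedent and it comes from a different core, so the account allows for some shrinkage of the effect. On that basis the value of compound 4 is estimated at 90000 nM, with a plausible range from 30000 nM to 250000 nM.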

Compound 4, half-maximal inhibitory concentration: > 200000 nM
Compound 4 was reported as a limit; the forecaster's own chance of this, stated with the estimate: 15%; middle value at least 2.2-fold (0.34 log units) away from the limit.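

In this assay compound 4 gives > 200000 nM, which is a limit of the assay and not a number. Chloro in place of bromo on the core of compound 3 gives an at least 1.0-fold higher number from compound 3 to compound 4 (0.00 log units; that floor lies within the scatter), so the lower number seen on the core of compound 2 does not carry over to this second core, and the two steps differ: the same change on two cores in this assay, a 2.9-fold lower number (0.46 log units; beyond the scatter) from compound 2 to compound 1 and an at least 1.0-fold higher number (0.00 log units; that floor lies within the scatter) from compound 3 to compound 4, at least 2.9-fold (0.46 log units) apart, beyond the scatter of two such steps. The methyl on the amide-type nitrogen, now with chloro on the ring, gives an at least 50-fold higher number from compound 1 to compound 4 (1.70 log units; beyond the scatter), but this step and the chloro step on the second core are floors rather than sizes, so the result does not show how large the chloro step really is or whether compound 4 truly stands apart from compound 3, and with one pair per core it shows only that the two exchanges do not add up in the same way on these compounds: the same change on two cores in this assay, a 17-fold higher number (1.24 log units; beyond the scatter) from compound 2 to compound 3 and an at least 50-fold higher number (1.70 log units; beyond the scatter) from compound 1 to compound 4, at least 2.9-fold (0.46 log units) apart, beyond the scatter of two such steps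

The compounds shown leave open whether a fluoro or a methoxy group in the same place on the aromatic ring would follow the pattern of the core of compound 2 or that of the second core. They also leave open how an ethyl group or a longer chain on the amide-type nitrogen would behave in this assay, and whether any such compound would return a number rather than a limit.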